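Replacing tert-butyl with oxan-3-yl: an expected solubility gain

The source may report more compounds than this note shows. Statements on the series, on what has been measured and on what is new or still open speak of the compounds shown alone.

Of the compounds shown here, three built on one shared core have been measured in a physicochemical assay for solubility, read by LC-MS, in phosphate buffer, measured as kinetic solubility, with a stated time of 24 h, at 25 degrees C, at pH 7.4; on this read-out lower numbers stand for lower solubility and higher numbers for higher solubility. Compound 1 `Nc1nccc(-c2cc(OC3CCOC3)c3c(N)n[nH]c3c2)n1` carries an oxolan-3-yl group on an oxygen on an aromatic ring and gives 751000 nM. Compound 2 `Nc1nccc(-c2cc3c4c(n[nH]c4c2)Nc2ccncc2O3)n1`, whose core is altered elsewhere, gives 10000 nM. Compound 3 `CC(C)(C)Oc1cc(-c2ccnc(N)n2)cc2[nH]nc(N)c12` carries a tert-butyl group on that oxygen and gives 68000 nM; of the three numbers it stands second highest, with only compound 1 above it and compound 2 below it.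

Among the measured compounds shown here, only one measured step joins two compounds that differ in a single place: an 11-fold lower number from compound 1 to compound 3 (1.04 log units; beyond the scatter), where tert-butyl replaced oxolan-3-yl on an oxygen on an aromatic ring.

Compound 4 `Nc1nccc(-c2cc(OC3CCCOC3)c3c(N)n[nH]c3c2)n1` differs from compound 3 in one place: oxan-3-yl in place of tert-butyl on an oxygen on an aromatic ring. This change is close to the reverse of the measured step, except that the incoming ring has one member more than the oxolan-3-yl of compound 1. For the measured compounds named here, the step from compound 3 to compound 4 is therefore expected to be an increase, a 5.1-fold higher number from compound 3 to compound 4 (0.71 log units; beyond the scatter), judged a little smaller than an 11-fold lower number from compound 1 to compound 3 (1.04 log units; beyond the scatter) since the entering ring is larger than the one in compound 1. Compound 4 is estimated to give 350000 nM, expected to lie between 120000 nM and 800000 nM.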

Compound 4, solubility: 1000000 nM
Estimate against measurement, compound 4: 2.9-fold (0.46 log units) below, and the stated range ends below it.
By their numbers in this assay, from the lowest: compound 2; then compound 3; then compounds 1 and 4 (each within the scatter of the next).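

With this assay as the read-out, oxan-3-yl in place of tert-butyl on an oxygen on an aromatic ring gives a 15-fold higher number from compound 3 to compound 4 (1.17 log units; beyond the scatter), so a second ring now stands apart from tert-butyl at this place, in the same sense as the earlier step read in reverse, an 11-fold lower number from compound 1 to compound 3 (1.04 log units; beyond the scatter). The extra ring member makes no readable difference, since oxan-3-yl in place of oxolan-3-yl gives a 1.3-fold higher number from compound 1 to compound 4 (0.12 log units; within the scatter), and the five-membered and six-membered rings cannot be told apart on this read-out. Among the three compounds that differ only at this oxygen, the dividing line therefore falls between tert-butyl and the two rings, not between the two rings themselves, and none of the three goes against this.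

These compounds cannot separate the part played by the ring from that of its oxygen, a question that a carbon-only ring such as cyclopentyl, an open chain such as 2-methoxyethyl, or a ring with an amine such as piperidin-4-yl could address. No measurement shown here accounts for the size of these steps.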